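Working notes on the series: carbonyl aryl change on compound 2

This account rests on a few compounds, and the source may have more. Where it says the series, first, only, none or still open, it means among the compounds named here.

Two compounds of the shared core have numbers in a functional assay on NCI/ADR-RES cells (Homo sapiens) for inhibition, read by sulforhodamine B assay, with a stated time of 48 h; on this read-out lower numbers stand for stronger inhibition of growth and higher numbers for weaker inhibition of growth. Compound 1 `COc1ccc(-c2cc(/C=C/C(=O)c3ccc(N)cc3)[nH]n2)cc1` gives 15500 nM in this assay. Compound 2 `COc1cc(-c2cc(/C=C/C(=O)c3ccc(N)cc3)[nH]n2)cc(OC)c1OC` gives 65800 nM in this assay. Compound 2 stands at the higher of the two numbers, and its gap to compound 1 lies beyond the scatter, so compound 2 is the weaker of the pair in this assay.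

Compound 3 `COc1cc(-c2cc(/C=C/C(=O)c3ccc(Cl)c(Cl)c3)[nH]n2)cc(OC)c1OC` keeps the whole of compound 2 apart from the group on the carbonyl carbon: 3,4-dichlorophenyl in place of 4-aminophenyl on a carbonyl carbon. Within the data shown here, no measured pair of the series shows this change, so its effect is not known from the numbers so far; the only variation measured is elsewhere on the core. A change of either direction is possible, and nothing here argues for a step beyond the scatter. Compound 3 is expected to give roughly 45000 nM in this assay, with a plausible range from 12000 nM to 150000 nM. The step of a 1.5-fold lower number from compound 2 to compound 3 (0.17 log units; within the scatter) is thus estimated to stay within the usual scatter, with some chance that only a limit is reported for compound 3.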

Compound 3, concentration for total growth inhibition: > 100000 nM
Compound 3 was reported as a limit; the forecaster's own chance of this, stated with the estimate: 20%; middle value at least 2.2-fold (0.34 log units) from the limit.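

In this assay, compound 3 is reported only as a limit, > 100000 nM. Among these compounds, this is the first measured change on the carbonyl carbon: 3,4-dichlorophenyl in place of 4-aminophenyl gives an at least 1.5-fold higher number from compound 2 to compound 3 (0.18 log units; that floor lies within the scatter), so the floor of this step does not by itself separate the two compounds, and the reading gives no sign of stronger inhibition of growth from this swap. The size of the change is therefore bounded on one side only, and this position cannot yet be ranked by a number for the dichlorinated compound: the limit of > 100000 nM in this assay, at which 1 of the 3 values shown sits.

The pair does not separate the loss of the amine from the entry of the two chlorine atoms, as both happen in one step on the same phenyl ring. Also open, from the compounds shown here alone, is how a plain phenyl, a single chlorine atom, a hydroxyl group or a carboxylic acid on that ring would read in this assay, and whether any group on the carbonyl carbon can bring a number lower than that of the 4-aminophenyl compounds.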